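Sulfur side chains: the step to compound 4

The source may hold more compounds than are shown below. What is called first, only, known or untested is meant among the compounds shown, and "the series" means these compounds.

In a functional assay on HT cells (Homo sapiens) for antiproliferative activity, read by fluorescence, with a stated time of 72 h (on this read-out lower numbers stand for stronger inhibition of growth and higher numbers for weaker inhibition of growth), compound 1 (`CC(C)c1n[nH]c2c(NCc3ccc(-c4ccccn4)cc3)nc(SCCN)nc12`) gives 22 nM, compound 2 (`COCSc1nc(NCc2ccc(-c3ccccn3)cc2)c2[nH]nc(C(C)C)c2n1`) gives 340 nM and compound 3 (`CC(C)c1n[nH]c2c(NCc3ccc(-c4ccccn4)cc3)nc(SC3CCCCC3N)nc12`) gives 139 nM, the middle of the three numbers. Compound 4 (`CCC(O)CSc1nc(NCc2ccc(-c3ccccn3)cc2)c2[nH]nc(C(C)C)c2n1`) carries 2-hydroxybutyl in place of 2-aminocyclohexyl on a sulfur. Among the measured compounds shown here, three measured steps bear on this. The 2-aminocyclohexyl group gave a 6.3-fold higher number from compound 1 to compound 3 (0.80 log units; beyond the scatter), a modest step. For the measured compounds named here, compound 2, the only measured compound without an amino group on the sulfur chain, stands at the high end, with a large 15-fold higher number from compound 1 to compound 2 (1.19 log units; beyond the scatter) and a modest 2.4-fold lower number from compound 2 to compound 3 (0.39 log units; beyond the scatter). Compound 4 also lacks that amino group, so a small move toward a higher number is expected, possibly within the scatter. The expected step is a 1.6-fold higher number from compound 3 to compound 4 (0.20 log units; within the scatter). For compound 4 the estimate is 220 nM, with an expected range of 80 nM to 600 nM.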

Compound 4, concentration for 50% growth inhibition: 273 nM
Beside the measured number, compound 4's estimate is 1.2-fold (0.09 log units) below it, and the stated range covers the measured number.
By their numbers in this assay, from the lowest: compound 1; then compounds 3, 4 and 2 (each within the scatter of the next, the first and the last beyond it).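

The 2-hydroxybutyl chain on the sulfur cannot be told apart from the 2-aminocyclohexyl chain (a 2.0-fold higher number from compound 3 to compound 4 (0.29 log units; within the scatter)) or the methoxymethyl chain (a 1.2-fold lower number from compound 2 to compound 4 (0.10 log units; within the scatter)), so an amino group on the chain does not by itself set compound 3 apart from compound 4. Only the 2-aminoethyl chain stands clear of the hydroxyl-bearing chain (a 12-fold higher number from compound 1 to compound 4 (1.09 log units; beyond the scatter)). Nothing measured here accounts for these steps. Open, going by these compounds, is whether the hydroxyl or the branching separates compound 4 from compound 1, which a 2-hydroxyethyl chain on the sulfur would test.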